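Replacing the Sulfur-Bound Group of Compound 1

A few compounds are considered here, and "the series" means these few. Any claim that something is new, unique, unknown or untested is made for them only; others in the source may bear on it.

Three measured compounds share one core and differ in what hangs from the sulfur-bound carbon or from the ether oxygen. In an assay on CHO cells for displacement of a labelled ligand from adenosine receptor A3 (Homo sapiens), read by scintillation counting, with a stated time of 120 min, tested at 1 uM (on this read-out higher numbers stand for more inhibition at the one concentration tested (going by the name of the read-out) and lower numbers for less inhibition), compound 1 `N#Cc1c(N)nc(SCc2cccc(C(N)=O)c2)c(C#N)c1-c1ccc(OCC2CC2)cc1` gives 1%, the lowest of the three numbers. Compound 2 `CC(C)COc1ccc(-c2c(C#N)c(N)nc(SCC(N)=O)c2C#N)cc1` gives 9% in this assay, a number within the scatter of that of compound 1. Compound 3 `CCOc1ccc(-c2c(C#N)c(N)nc(SCC(N)=O)c2C#N)cc1` gives 20%, which stands beyond the scatter above compound 1. For the measured compounds named here, the only one-place step between measured compounds is a number 11 percentage points higher from compound 2 to compound 3 (beyond the scatter); it concerns the chain on the ether oxygen, not the group on the sulfur-bound carbon, so it does not bear on the change considered here.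

Compound 4 `N#Cc1c(N)nc(SCC2=NCCN2)c(C#N)c1-c1ccc(OCC2CC2)cc1` differs from compound 1 by a group of 5 heavy atoms (3 carbon, 2 nitrogen; one five-membered non-aromatic ring with 2 hetero atoms) in place of a group of 9 heavy atoms (7 carbon, 1 nitrogen, 1 oxygen; one six-membered aromatic ring of carbon only), on a saturated chain carbon bound to a sulfur. Going by the values given here, no measured pair isolates a change at this position, so the data give no anchor for its size or direction. The expected step is therefore a number 9 percentage points higher from compound 1 to compound 4 (within the scatter), kept within the scatter. Compound 4 is estimated at 10%, with a range from 0% to 30%.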

Compound 4, a percentage reported as inhibition, at one concentration (the size of the read-out at that concentration, not a potency): 6%
Estimate against measurement, compound 4: 4 percentage points above; measured number inside the range.
By their numbers in this assay, from the lowest: compounds 1, 4 and 2 (each within the scatter of the next); then compound 3.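

In this assay, for the compounds shown here, the one step at this position is a number 5 percentage points higher from compound 1 to compound 4 (within the scatter). Replacing 3-carbamoylphenyl, a group of 9 heavy atoms with a six-membered aromatic ring, by a group of 5 heavy atoms with a five-membered non-aromatic ring therefore leaves no readable difference at the one concentration tested, so this exchange on a saturated chain carbon bound to a sulfur gives no sign of either group being preferred. Nothing in the available data offers an explanation for this result.

As far as these compounds go, since this is a reading at a single concentration, it remains open whether the two compounds would also stay within the scatter of each other at other concentrations. From the compounds shown here alone, it is also open whether an amine, a carboxylic acid or a longer chain at this place would give a number beyond the scatter of compound 1.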